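Benzyloxy in place of 5-(trifluoromethyl)pyridin-2-yl on compound 1

The compounds below may be only part of what the source reports. "The series", "measured", "known", "first", "only" and "open" are said of these compounds alone.

In an ADME assay on the whole organism (Rattus norvegicus), at a dose of 2 mg/kg by the oral route (a higher number here means more compound in the circulation at the dose given, a lower number less compound in the circulation), compound 1 (`COc1cc(OCc2cccc(-c3ccc(C(F)(F)F)cn3)c2)c2cc(-c3cn4nc(OC)sc4n3)oc2c1`) stands highest at 459 ng.h/mL of the two measured compounds. Compound 2 (`COc1cc(OCc2csc(-c3ccc(S(C)(=O)=O)cc3)n2)c2cc(-c3cn4nc(OC)sc4n3)oc2c1`) gives 148 ng.h/mL as the lower number, a gap beyond the scatter. Compound 3 (`COc1cc(OCc2cccc(OCc3ccccc3)c2)c2cc(-c3cn4nc(OC)sc4n3)oc2c1`) carries benzyloxy in place of 5-(trifluoromethyl)pyridin-2-yl on an aromatic carbon. Among the measured compounds shown here, no measured step covers this change, so the expectation is loose. A modest fall in this assay is expected, with the estimated 1.8-fold lower number from compound 1 to compound 3 (0.25 log units; within the scatter) probably not clearly beyond the scatter. For compound 3 the estimate is 260 ng.h/mL (expected range 70 ng.h/mL to 850 ng.h/mL).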

Compound 3, area under the concentration-time curve: 339 ng.h/mL
Beside the measured number, compound 3's estimate is 1.3-fold (0.12 log units) below it; the measured number falls inside the stated range.
By their numbers in this assay, from the lowest: compound 2; then compounds 3 and 1 (each within the scatter of the next).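

At this position, on an aromatic carbon meta to a large group, benzyloxy in place of 5-(trifluoromethyl)pyridin-2-yl gives a 1.4-fold lower number from compound 1 to compound 3 (0.13 log units; within the scatter) in this assay. The two groups therefore cannot be told apart in this read-out, although the ring nitrogen and trifluoromethyl both leave with the exchange. Nothing at hand explains this result. This single step cannot show whether the ring nitrogen or the trifluoromethyl matters on its own. Going by these compounds, how an amine or a carboxylic acid at this position would read also remains open.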